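The source may hold more compounds than are shown below. What is called first, only, known or untested is meant among the compounds shown, and "the series" means these compounds.

Of the compounds shown here, three sharing one core have been tested in a functional assay on K562 cells (Homo sapiens) for cytotoxicity, read by MTT assay, with a stated time of 24 h; a higher number here means a weaker inhibitor, a lower number a stronger inhibitor. Compound 1 `C=C1CC[C@H]2C(C)(C)CCC[C@]2(C)[C@H]1CCC(C)CC(=O)O` carries the bare core; in this assay compound 1 gives > 200000 nM, which is a limit of the assay rather than a number. Compound 2 `COc1ccc(/C=C2\CC[C@H]3C(C)(C)CCC[C@]3(C)[C@H]2CCC(C)CC(=O)O)cc1` adds a 4-methoxyphenyl group; in this assay compound 2 gives > 200000 nM, again a limit rather than a number. Compound 3 `CC(CC[C@H]1/C(=C/c2ccc([N+](=O)[O-])cc2)CC[C@H]2C(C)(C)CCC[C@]12C)CC(=O)O` has a nitro in place of methoxy on an aromatic carbon; in this assay compound 3 gives > 200000 nM, also a limit. The size of the step that the two limits leave unreadable from compound 2 to compound 3 cannot be read because of the limit of > 200000 nM in this assay, at which 3 of the 3 values shown sit. Compound 2 thus stands at the limit, and the two other values shown stand there as well.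

Compound 4 `COc1ccc(/C=C2\CC[C@H]3C(C)(C)CCC[C@]3(C)[C@H]2CCC(C)CC(=O)O)cc1OC` differs from compound 2 by methoxy in place of hydrogen on an aromatic carbon. Within the data shown here, only one measured step bears on this kind of change, a step that the two limits leave unreadable from compound 2 to compound 3, and its size is not readable because of the limit of > 200000 nM in this assay, at which 3 of the 3 values shown sit. Among the measured compounds shown here, no measured step shows any movement in this assay beyond the scatter. Compound 4 is therefore expected to remain at the limit, the expected step that the limit leaves unreadable from compound 2 to compound 4 meaning none beyond the scatter. The estimate for compound 4 in this assay is 250000 nM, between 60000 nM and 1000000 nM.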

Compound 4, half-maximal inhibitory concentration: > 200000 nM
Compound 4: only a limit was reported; the forecaster's own chance of this, stated with the estimate: 80%; the middle value lies beyond the limit too.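

Compound 4 gives > 200000 nM, which is a limit and not a number. The steps to compound 4 from compound 2 and from compound 3 therefore cannot be read, because all the values share that ceiling: the limit of > 200000 nM in this assay, at which 4 of the 4 values shown sit.

The compounds shown leave open which change to the shared core, if any, would give a measurable value in this assay.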